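A Fluorinated Amide in Place of a Small Methyl

The compounds below may be only part of what the source reports. "The series", "measured", "known", "first", "only" and "open" are said of these compounds alone.

Of the compounds shown here, three of a shared core have been tested in an assay on HEK293 cells for positive allosteric modulation of metabotropic glutamate receptor 5 (Homo sapiens), read by FLIPR, with a stated time of 1 h; on this read-out higher numbers stand for an effect only at larger amounts of compound and lower numbers for an effect already at smaller amounts. Compound 1 `O=C1c2sc(C#Cc3ccccc3)nc2CN1C1CC1` reaches only a limit of the assay, giving > 10000 nM. For the measured compounds named here, compound 2 `CN1CCc2nc(C#Cc3ccccc3)sc2C1` gives the sole actual number of the set, 34 nM, in this assay. Compound 3 `O=C(C1CCC1)N1CCc2nc(C#Cc3ccccc3)sc2C1`, too, reaches only a limit of the assay, giving > 10000 nM. Going by the values given here, compound 2 therefore stands alone as the one with a measured value, while the other two sit at the limit of > 10000 nM in this assay, at which 2 of the 3 values shown sit.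

Among the compounds with values here, the single measured step bearing on the change at hand runs from compound 2 to compound 3, where cyclobutylcarbonyl replaces methyl on an amine nitrogen in a ring: an at least 290-fold higher number from compound 2 to compound 3 (2.46 log units; beyond the scatter).

Compound 4 `O=C(C1CC(F)C1)N1CCc2nc(C#Cc3ccccc3)sc2C1` has not yet been measured in this assay. It differs from compound 2 as follows: (3-fluorocyclobutyl)carbonyl in place of methyl on an amine nitrogen in a ring. This change matches the step from compound 2 to compound 3 in kind, with a fluorine added to the four-membered ring. Given how large that step was, a comparably large step in the same direction is expected, a 440-fold higher number from compound 2 to compound 4 (2.64 log units; beyond the scatter), and compound 4 is estimated at 15000 nM, ranging from 3000 nM to 60000 nM, with a good chance that the assay again reports only a limit.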

Compound 4, half-maximal effective concentration: 85 nM
For compound 4 the middle estimate is 180-fold (2.25 log units) above the measured one, and the stated range ends above it.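

In this assay, an amide on this amine nitrogen in a ring is not ruled out by itself: the much larger (3-fluorocyclobutyl)carbonyl group in place of methyl brings only a modest change, a 2.5-fold higher number from compound 2 to compound 4 (0.40 log units; beyond the scatter), though still one beyond the usual scatter. Compound 3 gives > 10000 nM, which is a limit of the assay and not a number. Set against that limit, a single fluoro in place of hydrogen on a saturated ring carbon separates a compound with a measured effect from one without, an at least 110-fold lower number from compound 3 to compound 4 (2.07 log units; beyond the scatter), so at this position the outcome hangs on a small detail of the amide group and not simply on the presence of a carbonyl.

The compounds shown do not explain why one fluorine matters so much, since they offer no measurement that could separate possible causes. From the compounds shown here alone, it also stays open whether a hydroxyl or a second fluorine on the same four-membered ring, or a cyclopentylcarbonyl group in its place, would keep the number close to that of compound 4.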